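A few compounds are considered here, and "the series" means these few. Any claim that something is new, unique, unknown or untested is made for them only; others in the source may bear on it.

Of the compounds shown here, three of a shared core have been measured in a functional assay on HCT-15 cells (Homo sapiens) for cytotoxicity, read by sulforhodamine B assay, with a stated time of 72 h; on this read-out lower numbers stand for stronger inhibition of growth and higher numbers for weaker inhibition of growth. Compound 1 `O=C(Nc1ccccc1C(F)(F)F)C1CCc2ccccc2N1C(=O)c1cccc(Cl)c1` gives 797 nM and stands lowest of the three numbers. Compound 3 `CCC(=O)N1c2ccccc2CCC1C(=O)Nc1cc(C(F)(F)F)cc(C(F)(F)F)c1` gives 7620 nM, a number that lies beyond the usual scatter above that of compound 1. Compound 2 `COc1ccc(NC(=O)C2CCc3ccccc3N2)cc1` gives 50200 nM, the furthest from compound 1, again well beyond the scatter.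

The next compound, compound 4 `CCC(=O)N1c2ccccc2CCC1C(=O)Nc1ccccc1C(F)(F)F`, has not yet been measured. It differs from compound 1 in one place: ethyl in place of 3-chlorophenyl on a carbonyl carbon. Going by the values given here, no pair of measured compounds differs in exactly this way, so the size of this step is not known directly. Compound 4 carries the same propanoyl group as compound 3, which gives 7620 nM, but compound 3 also differs from compound 1 elsewhere, so its number can only hint that the propanoyl compounds tend to sit higher.

On that basis, the step in this assay is expected to be a 3.8-fold higher number from compound 1 to compound 4 (0.58 log units; beyond the scatter), a rise of modest size. Compound 4 is therefore estimated at 3000 nM, with a likely range from 1000 nM to 10000 nM.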

Compound 4, concentration for 50% growth inhibition: > 80000 nM
Compound 4: no number, only a limit (the forecaster's own chance of this, stated with the estimate: 5%); middle value at least 26-fold (1.42 log units) from the limit.
By their numbers in this assay, from the lowest: compound 1; then compound 3; then compound 2. At a limit, above all of these: compound 4.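

Going by these compounds alone, until now, no pair of compounds isolated the group on the carbonyl carbon whose other neighbour is the amide-type nitrogen in a ring. In this assay, placing ethyl there instead of 3-chlorophenyl gives an at least 100-fold higher number from compound 1 to compound 4 (2.00 log units; beyond the scatter), a large step beyond the usual scatter, so in this pair the 3-chlorophenyl group is needed for the growth inhibition seen with compound 1. From the compounds shown here alone, compound 4 gives > 80000 nM, which is a limit of the assay and not a number, so the true size of the step stays unknown and only its lower bound can be read, with the result resting on this one value: the limit of > 80000 nM in this assay, at which 1 of the 4 values shown sits.

The compounds shown do not separate the part played by the ring from that of the chlorine on it, so a plain phenyl, a longer chain such as butyl, or an amine at this place could each help to tell these apart. Going by these compounds, whether the same change has as large an effect alongside the two trifluoromethyl groups of compound 3 also stays open.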